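The source may report more compounds than this note shows. Statements on the series, on what has been measured and on what is new or still open speak of the compounds shown alone.

Measured in an assay on isolated protein for inhibition of N-acylethanolamine-hydrolyzing acid amidase (Homo sapiens), read by fluorescence, with a stated time of 90 min; on this read-out higher numbers stand for weaker inhibition and lower numbers for stronger inhibition:
compound 1 `COc1ccc(-c2ccc(C(=O)N[C@H]3C[C@@H](N=C=S)C3)nc2)cc1F` gives 26.6 nM
compound 2 `COc1ccc(CCCCCC(=O)N[C@H]2C[C@@H](N=C=S)C2)cc1` gives 22.5 nM

Compound 1 carries the higher of the two numbers, but compound 2 sits within the scatter of it, so on this assay the two cannot be told apart. Both hold the same amide-linked cyclobutyl isothiocyanate end, joined either to a biaryl or to a six-carbon chain bearing the methoxyphenyl, and neither arrangement gives a clear advantage.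

Compound 3 `COc1ccc(-c2ccc(C(=O)N[C@H]3C[C@@H](N=C=S)C3)nc2)cc1` differs from compound 1 in a single place: hydrogen in place of fluoro on an aromatic carbon. Among the compounds with values here, no pair of measured compounds differs by a change of this kind, so no measured step can be used as a guide. The change removes one heavy atom at a position ortho to a methoxy group and meta to a large group, leaving the rest of compound 1 untouched. The expected step is a 1.3-fold higher number from compound 1 to compound 3 (0.12 log units; within the scatter), which is not expected to go beyond the scatter, with a slight lean towards a weaker number. Compound 3 is therefore estimated at 35 nM, with a range from 12 nM to 100 nM.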

Compound 3, half-maximal inhibitory concentration: 7.6 nM
Compound 3: middle estimate off by 4.6-fold (0.66 log units), on the high side; measured number outside the range, below it.
By their numbers in this assay, from the lowest: compound 3; then compounds 2 and 1 (each within the scatter of the next).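

In this assay, within the data shown here, this aromatic carbon, ortho to a methoxy group, proves sensitive to a small change: hydrogen in place of fluoro gives a 3.5-fold lower number from compound 1 to compound 3 (0.54 log units; beyond the scatter) and this is the only step so far, as well as one that lies beyond the scatter. The earlier compounds shown here could not show this, since no measured pair differed in one place; here the loss of one heavy atom, with the rest of compound 1 untouched, is enough to move the number. The fluoro is therefore not required for inhibition in this pair, and the compound with hydrogen at this carbon carries the lower number, although no measurement at hand bears on the cause of the step.

Still open, as far as these compounds go, is whether chloro, methyl or hydroxyl at this same carbon would give a number closer to that of compound 1 or that of compound 3. A single pair also leaves open whether hydrogen in place of fluoro would give a similar step at the other carbons of this ring or on a different core.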